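The source may hold more compounds than are shown below. What is called first, only, known or untested is meant among the compounds shown, and "the series" means these compounds.

Measured compounds:
compound 1 `CCCCC(=O)Oc1ccc2oc(/C=C/[S+](C)[O-])cc(=O)c2c1`; in a functional assay on A549 cells (Homo sapiens) for cytotoxicity, with a stated time of 48 h (a lower number here means a stronger inhibitor, a higher number a weaker inhibitor), compound 1 gives 2400 nM.
compound 2 `CCC(=O)Oc1ccc2oc(/C=C/[S+](C)[O-])cc(=O)c2c1`; compound 2 gives 2400 nM.
compound 3 `CCCOc1ccc2oc(/C=C/[S+](C)[O-])cc(=O)c2c1`; compound 3 gives 1100 nM.

Compound 4 `COc1ccc2oc(/C=C/[S+](C)[O-])cc(=O)c2c1` has not been measured. It differs from compound 3 by hydrogen in place of ethyl on a saturated chain carbon bound to an oxygen on an aromatic ring. A change of the same kind, (hydrogen in place of ethyl on a saturated chain carbon, two bonds along the chain from a carbonyl carbon), was made between two measured compounds, and it gave no change at the digits printed from compound 1 to compound 2 (within the scatter). The two places are not the same word for word: one is on a saturated chain carbon two bonds along the chain from a carbonyl carbon, the other on a saturated chain carbon bound to an oxygen on an aromatic ring, so this is the same kind of change, not the same. The cores also differ, by propyl in place of butylcarbonyl on an oxygen on an aromatic ring, with a 2.2-fold lower number from compound 1 to compound 3 (0.34 log units; beyond the scatter). Because no change at the digits printed from compound 1 to compound 2 (within the scatter), compound 4 is expected to sit near compound 3, with an expected step of a 1.2-fold higher number from compound 3 to compound 4 (0.07 log units; within the scatter). The estimate for compound 4 is 1300 nM, between 600 nM and 3000 nM.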

Compound 4, half-maximal inhibitory concentration: 1600 nM
Compound 4: middle estimate off by 1.2-fold (0.09 log units), on the low side, and the stated range covers the measured number.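

Replacing an ethyl with hydrogen on the chain gives a 1.5-fold higher number from compound 3 to compound 4 (0.16 log units; within the scatter) in this assay, and the same kind of change on the other core does not read differently: the same change on two cores in this assay, no change at the digits printed (within the scatter) from compound 1 to compound 2 and a 1.5-fold higher number (0.16 log units; within the scatter) from compound 3 to compound 4, 1.5-fold (0.16 log units) apart, within the scatter of two such steps. Replacing propanoyl or butylcarbonyl on the oxygen with methyl gives similarly small steps, a 1.5-fold lower number from compound 2 to compound 4 (0.18 log units; within the scatter) and a 1.5-fold lower number from compound 1 to compound 4 (0.18 log units; within the scatter). Among the compounds shown here, the change therefore carried over between these two cores without a detectable difference, but with only two pairs, both within the scatter, this does not show that it would behave the same way on other cores.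

The compounds shown leave open what a chain ending in an amine or a carboxylic acid would do on this oxygen. They also leave open whether a much longer chain would move the number.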